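Ethylamide in place of the methylpiperazine amide

This account rests on a few compounds, and the source may have more. Where it says the series, first, only, none or still open, it means among the compounds named here.

Measured so far:
compound 1 `COc1ccc(/C=C/c2cc(OC)cc(OC)c2/C=C/C(=O)N2CCN(C)CC2)cc1` gives 5670 nM;
compound 2 `COc1ccc(/C=C/c2cc(OC)cc(OC)c2/C=C/C(=O)N2CCCCC2C)cc1` gives 7660 nM;
compound 3 `COc1ccc(/C=C/c2cc(OC)cc(OC)c2/C=C/C(=O)N2CCCC2)cc1` gives 9280 nM.

These three share a core and differ only in the amine on the carbonyl carbon; in a functional assay on B16-F10 cells (Mus musculus) for inhibition, read by MTT assay, with a stated time of 48 h (on this read-out lower numbers stand for stronger inhibition and higher numbers for weaker inhibition), compound 1 stands apart from the others by a 1.4-fold higher number from compound 1 to compound 2 (0.13 log units; within the scatter) and a 1.6-fold higher number from compound 1 to compound 3 (0.21 log units; within the scatter), both inside the scatter, as is a 1.2-fold higher number from compound 2 to compound 3 (0.08 log units; within the scatter). Compound 4 `CCNC(=O)/C=C/c1c(/C=C/c2ccc(OC)cc2)cc(OC)cc1OC` makes a change of the same kind: ethylamino in place of 4-methylpiperazin-1-yl on a carbonyl carbon. Every measured step at this place stayed within the scatter, so those steps point to a small change at most; none of them, however, removed the ring or brought in a hydrogen-bond donor. For compound 4 a step of about a 1.6-fold higher number from compound 1 to compound 4 (0.20 log units; within the scatter) is expected, with wide uncertainty, giving an estimated 9000 nM between 3500 nM and 25000 nM.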

Compound 4, half-maximal inhibitory concentration: 6990 nM
Compound 4: middle estimate off by 1.3-fold (0.11 log units), on the high side; low and high end bracket the measured number.
By their numbers in this assay, from the lowest: compounds 1, 4, 2 and 3 (each within the scatter of the next).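

Taking away the ring and bringing in the amide hydrogen, a hydrogen-bond donor, on this carbonyl carbon still leaves this assay within the scatter, with a 1.2-fold higher number from compound 1 to compound 4 (0.09 log units; within the scatter). The open-chain ethylamino group is also within the scatter of both other ring amides, with a 1.3-fold lower number from compound 3 to compound 4 (0.12 log units; within the scatter) and a 1.1-fold lower number from compound 2 to compound 4 (0.04 log units; within the scatter). Across these four compounds, neither a ring nor the amide hydrogen is needed to keep the number at this level, and no measurement here bears on the reason. Still open, on these data alone, is whether a carboxylic acid in place of the amide, or a longer chain in place of ethylamino, would move the number beyond the scatter.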